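The compounds below may be only part of what the source reports. "The series", "measured", "known", "first", "only" and "open" are said of these compounds alone.

Compound 1 `CN1Cc2cc(-c3ccc(-c4cncc(NS(=O)(=O)c5ccc(F)cc5F)c4)s3)cnc2C1=O` - 20300 ug/mL
Compound 2 `CN1Cc2cc(-c3ccc(-c4cncc(NS(=O)(=O)c5cccc(C(F)(F)F)c5)c4)s3)cnc2C1=O` - 20300 ug/mL
Compound 3 `COc1ncc(-c2ccc(-c3cnc4c(c3)CN(C)C4=O)s2)cc1NS(=O)(=O)c1ccccc1C(F)(F)F` - 7340 ug/mL

In a physicochemical assay for solubility, read by HPLC (a higher number here means a more soluble compound, a lower number a less soluble compound), compound 3 holds the lowest of the three numbers, and its gap to each of the other two lies beyond the scatter. Compound 4 `CN1Cc2cc(-c3ccc(-c4cncc(NS(=O)(=O)c5ccccc5C(F)(F)F)c4)s3)cnc2C1=O` keeps the sulfonyl group of compound 3 and has hydrogen in place of methoxy on an aromatic carbon. Going by the values given here, no measured step covers this change. Among the compounds with values here, the only measured step, no change at the digits printed from compound 1 to compound 2 (within the scatter), lies on the sulfonyl side, and it still bears on the estimate. Compound 1 and compound 2 both carry hydrogen at that carbon, so compound 4 is expected to land near them. An upward step just beyond the scatter is expected (a 2.2-fold higher number from compound 3 to compound 4 (0.34 log units; beyond the scatter)). Compound 4 is estimated at 16000 ug/mL (range 7500 ug/mL to 27000 ug/mL).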

Compound 4, solubility: 4280 ug/mL
Compound 4: the middle estimate sits 3.7-fold (0.57 log units) above what was measured; measured number below the stated range.
By their numbers in this assay, from the lowest: compounds 4 and 3 (each within the scatter of the next); then compounds 1 and 2 (each within the scatter of the next).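

In this assay, hydrogen in place of methoxy at this carbon next to the ring nitrogen gives a 1.7-fold lower number from compound 3 to compound 4 (0.23 log units; within the scatter), so the change has no readable effect at this position with 2-(trifluoromethyl)phenyl on the sulfonyl sulfur. The sulfonyl aryl group, silent in the earlier step, now separates compounds: the 2-(trifluoromethyl)phenyl swap gives a 4.7-fold lower number from compound 2 to compound 4 (0.68 log units; beyond the scatter) and a 4.7-fold lower number from compound 1 to compound 4 (0.68 log units; beyond the scatter). No measurement here offers a reason for these steps.

Open, from the compounds shown here alone, is whether an amine or a carboxylic acid at this carbon would shift the number beyond the scatter. Also open, going by these compounds, is whether methoxy behaves alike with 3-(trifluoromethyl)phenyl or 2,4-difluorophenyl on the sulfonyl sulfur.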